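Swapping the phenoxy bridge for a benzyl in a coumarin amide

The compounds below may be only part of what the source reports. "The series", "measured", "known", "first", "only" and "open" are said of these compounds alone.

Of the compounds shown here, three have been measured in a functional assay on MCF7 cells (Homo sapiens) for antiproliferative activity; a lower number here means a stronger inhibitor, a higher number a weaker inhibitor. Compound 1 `COc1ccc(Oc2ccc3cc(NC(=O)c4ccc(OC(C)=O)c(CC=C(C)C)c4)c(=O)oc3c2C)cc1` gives 18200 nM. Compound 2 `COc1ccc(Oc2ccc3cc(NC(=O)c4ccc(O)c(CC=C(C)C)c4)c(=O)oc3c2C)cc1` gives 6510 nM, and compound 3 `COc1ccc(Cc2ccc3cc(NC(=O)c4ccc(OC(C)=O)c(CC=C(C)C)c4)c(=O)oc3c2C)cc1` gives 11500 nM. Compound 2 thus shows the lowest of the three numbers; the measured step is a 2.8-fold lower number from compound 1 to compound 2 (0.45 log units; beyond the scatter), while compound 3 lies within the scatter of compound 2, so no order between those two can be claimed.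

Compound 4 `COc1cccc(Cc2ccc3cc(NC(=O)c4ccc(O)c(CC=C(C)C)c4)c(=O)oc3c2C)c1` is not yet measured. Relative to compound 2 it carries 3-methoxybenzyl in place of 4-methoxyphenoxy on an aromatic carbon. Among the measured compounds shown here, one measured step bears on this: the same exchange of a phenoxy for a benzyl linker gave a 1.6-fold lower number from compound 1 to compound 3 (0.20 log units; within the scatter). For the measured compounds named here, no measured pair shows what shifting the methoxy group from the 4-methoxybenzyl to the 3-methoxybenzyl arrangement does, so that part of the change is untested.

The expectation for compound 4 is therefore a step of a 1.3-fold lower number from compound 2 to compound 4 (0.11 log units; within the scatter), within the scatter. Compound 4 is estimated at 5000 nM, with a likely range from 1500 nM to 16000 nM.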

Compound 4, half-maximal inhibitory concentration: 19700 nM
Compound 4: middle estimate off by 3.9-fold (0.60 log units), on the low side; the measured number lies above the stated range.
By their numbers in this assay, from the lowest: compounds 2, 3, 1 and 4 (each within the scatter of the next, the first and the last beyond it).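

In this assay, this exchange on the aromatic carbon ortho to a methyl group is not neutral: a 3.0-fold higher number from compound 2 to compound 4 (0.48 log units; beyond the scatter). The earlier linker exchange gave only a 1.6-fold lower number from compound 1 to compound 3 (0.20 log units; within the scatter), so this position responds to the group placed on it more than that step alone suggested. That earlier step differs from the new one in two ways, the methoxy arrangement and the acetyl on the oxygen, and nothing available explains the higher number of compound 4.

The compounds shown leave open whether the benzyl linker, the 3-methoxy arrangement or their combination with the free hydroxyl accounts for the step. They also leave open how this position would respond to an amine or a carboxylic acid on the benzyl ring in place of the methoxy group.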